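Ring substituent swap at the shared core

The source may hold more compounds than are shown below. What is called first, only, known or untested is meant among the compounds shown, and "the series" means these compounds.

Measured so far in a functional assay on UACC-257 cells (Homo sapiens) for antiproliferative activity, read by sulforhodamine B assay, with a stated time of 48 h; on this read-out higher numbers stand for weaker inhibition of growth and lower numbers for stronger inhibition of growth:
compound 1, `Nc1nn(C(=O)Nc2ccc(Cc3ccccc3)cc2)c2ccccc12`: 50900 nM
compound 2, `Nc1nn(C(=O)Nc2ccc(Cc3ccccc3)cc2)c2ccc(Cl)cc12`: limit, > 100000 nM
not yet measured: compound 3, `Nc1ccc2c(c1)c(N)nn2C(=O)Nc1ccc(Cc2ccccc2)cc1`

In this assay compound 1 gives 50900 nM. For compound 2 this assay reports only a limit, > 100000 nM, which is the assay's limit and not a number (the limit of > 100000 nM in this assay, at which 1 of the 2 values shown sits). For the measured compounds named here, the one step measured so far is an at least 1.9-fold higher number from compound 1 to compound 2 (0.29 log units; that floor lies within the scatter), so compound 2 stands at the weak end of the two values shown, with no number of its own.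

The move to compound 3 is amino in place of chloro on an aromatic carbon. Going by the values given here, no measured step involves an amino group at this place; the only related step is the hydrogen-to-chloro step from compound 1 to compound 2, whose size was at least the floor noted and lies within the scatter. Among the compounds with values here, the amino change therefore has no directly comparable precedent, and in this assay a step of no more than the usual scatter in either direction is expected, with compound 1 showing that a hydrogen-bearing ring at this place sits at 50900 nM.

Compound 3 is expected to give about 60000 nM, within 20000 nM to 200000 nM. That is an expected step of an at least 1.6-fold lower number from compound 2 to compound 3 (0.22 log units; that floor lies within the scatter).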

Compound 3, concentration for total growth inhibition: 29700 nM
Beside the measured number, compound 3's estimate is 2.0-fold (0.31 log units) above it; the range from low to high includes it.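

In this assay, for the compounds shown here, amino in place of chloro on this aromatic carbon gives an at least 3.3-fold lower number from compound 2 to compound 3 (0.52 log units; beyond the scatter), the first step that lies beyond the scatter, which shows that a change at this place can move the read-out measurably. From the compounds shown here alone, for compound 2 the value is a limit and not a number, so this step is a floor and its full size stays unknown: the limit of > 100000 nM in this assay, at which 1 of the 3 values shown sits. Amino in place of hydrogen gives a 1.7-fold lower number from compound 1 to compound 3 (0.23 log units; within the scatter), so amino is not separated from hydrogen at this place, and the one step beyond the scatter is the one that leaves chloro.

The compounds shown leave open how other groups at this place would read, for instance a methoxy group, a carboxylic acid or an acetamide, and so whether the read-out follows any trend across substituents or only separates chloro from amino. Also open, going by these compounds, is whether amino in place of chloro would give a step of similar size with a different group on the far phenyl ring of the shared core.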